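The compounds below may be only part of what the source reports. "The series", "measured", "known", "first", "only" and "open" are said of these compounds alone.

Compound 2 `COc1cc(-c2ccnc3cc(-c4ccccc4)nn23)cc(OC)c1OC` stands lowest of the two numbers in a functional assay on MCF7 cells (Homo sapiens) for inhibition, read by CCK-8 assay, with a stated time of 48 h (on this read-out lower numbers stand for stronger inhibition and higher numbers for weaker inhibition), where compound 2 gives 254 nM. Compound 1 `Cn1ccc2cc(-c3cc4nccc(-c5ccc(F)cc5)n4n3)ccc21` shows the nearest number: in this assay compound 1 gives 4580 nM, a difference beyond the scatter. Compound 3 `COc1cc(-c2ccnc3cc(-c4ccc5cnn(C)c5c4)nn23)cc(OC)c1OC` differs from compound 2 in one place: 1-methyl-1H-indazol-6-yl in place of phenyl on an aromatic carbon. For the measured compounds named here, no measured pair shows this exchange, so the step of a 1.6-fold higher number from compound 2 to compound 3 (0.20 log units; within the scatter) is only expected to be small, within or just beyond the scatter, with no firm direction. Compound 3 is therefore estimated at 400 nM, with a range from 100 nM to 1600 nM.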

Compound 3, half-maximal inhibitory concentration: 279 nM
The estimate for compound 3 lay 1.4-fold (0.16 log units) above the measured number, and the stated range covers the measured number.
By their numbers in this assay, from the lowest: compounds 2 and 3 (each within the scatter of the next); then compound 1.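

Putting 1-methyl-1H-indazol-6-yl in place of phenyl on this aromatic carbon gives a 1.1-fold higher number from compound 2 to compound 3 (0.04 log units; within the scatter) in this assay. For the compounds shown here, this is the first one-place comparison at this position, and it shows that the position accepts a second aromatic ring with 2 nitrogen and 2 hydrogen-bond acceptors without a change beyond the scatter. Nothing available bears on the reason for this result.

Going by these compounds, whether an amine, a carboxylic acid or a longer chain on this carbon would be accepted in the same way remains open. So does whether the same exchange would give a similar step in the other parts of compound 1.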